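The compounds below may be only part of what the source reports. "The series", "measured", "known", "first", "only" and "open" are said of these compounds alone.

Of the compounds shown here, two have so far been measured in an assay on IM-9 cells for binding affinity to Substance-P receptor (Homo sapiens); a lower number here means a stronger inhibitor, a higher number a weaker inhibitor. Compound 1 `Cc1ccccc1-c1c(C(=O)N(C)Cc2cc(C(F)(F)F)cc(C(F)(F)F)c2)n(C)c(=O)c2ccccc12` gives 1.3 nM in this assay, and compound 2 `COc1ccccc1CN(C)C(=O)c1c(-c2ccc(F)cc2)c2cccnc2c(=O)n1C` gives 2.5 nM in this assay. Compound 2 holds the higher of the two numbers, but its distance from compound 1 is within the scatter of repeated measurements, so the two cannot be told apart on these figures.

The next compound, compound 3 `CN(Cc1ccccc1Cl)C(=O)c1c(-c2ccc(F)cc2)c2cccnc2c(=O)n1C`, keeps the core of compound 2 and changes only the substituent on the benzyl ring: chloro in place of methoxy on an aromatic carbon. Among the measured compounds shown here, no measured pair of this kind is available to show how large such a change runs here, so its effect can only be anticipated. For the measured compounds named here, both compounds measured so far sit at the low end of the scale, and a single substituent swap on the benzyl ring is expected to move the number only modestly, if at all beyond the scatter. The step from compound 2 to compound 3 is expected to be a 1.6-fold higher number from compound 2 to compound 3 (0.20 log units; within the scatter). Compound 3 is therefore estimated at 4 nM in this assay, with a range from 1.5 nM to 12 nM.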

Compound 3, half-maximal inhibitory concentration: 32 nM
For compound 3 the middle estimate is 8.0-fold (0.90 log units) below the measured one, outside the stated range (above it).
By their numbers in this assay, from the lowest: compounds 1 and 2 (each within the scatter of the next); then compound 3.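

In this assay, the change of 2-methoxybenzyl to 2-chlorobenzyl, with the shared core left as it is, gives a 13-fold higher number from compound 2 to compound 3 (1.11 log units; beyond the scatter). Among the compounds shown here, this is the first measured step, and it shows that this one position on the benzyl ring is far from indifferent to what it carries: a single substituent swap there is enough to take the number well beyond the scatter. Nothing at hand bears on why the number rises with chloro in place of methoxy, and the step stands as an observation only.

On these data alone, a single step cannot say whether methoxy is unusually good at this position or chloro unusually poor, and how other groups there, such as hydroxy, ethoxy or an amine, would read remains open. As far as these compounds go, it also remains open whether the same swap would bring a step of similar size on the core of compound 1, or with the chloro or methoxy group placed elsewhere on the benzyl ring.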